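The source may hold more compounds than are shown below. What is called first, only, known or untested is meant among the compounds shown, and "the series" means these compounds.

Measured so far:
compound 1 `COc1cc(N)c(Cl)cc1C(=O)NC1CCNCC1`: > 100%
compound 2 `CC(C)n1c(=O)n(C(=O)NCCN2CCNCC2)c2ccccc21`: > 100%
compound 3 `COc1ccc2[nH]cc(C(=O)NCC3CCNCC3)c2c1`: 42%

In a functional assay on HEK293 cells for activation of 5-hydroxytryptamine receptor 4 (Homo sapiens), read by cAMP accumulation (on this read-out higher numbers stand for larger maximal responses and lower numbers for smaller maximal responses), compound 1 reaches only a limit of the assay, > 100%. Compound 2 likewise stops at a limit, > 100%. Among the measured compounds shown here, compound 3 is thus the one compound of the three that gives an actual number, 42%. The two others sit at a limit (the limit of > 100% in this assay, at which 2 of the 3 values shown sit). Compound 4 `COc1ccc2[nH]cc(C(=O)NC3CCNCC3)c2c1` is the next to be measured in this assay. It differs from compound 3 by piperidin-4-yl in place of (piperidin-4-yl)methyl on an amide-type nitrogen. For the measured compounds named here, no pair of measured compounds differing in one place is available to calibrate this step, so no step beyond the scatter is expected in either direction. Compound 4 is estimated at 45%, within 20% to 75%, which means an expected step of a number 3 percentage points higher from compound 3 to compound 4 (within the scatter).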

Compound 4, intrinsic activity: the largest response reached, in percent of the reference agonist's: 0%
Beside the measured number, compound 4's estimate is 45 percentage points above it; measured number below the stated range.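

In this assay, this place on the amide-type nitrogen proves highly sensitive: piperidin-4-yl in place of (piperidin-4-yl)methyl gives a number 42 percentage points lower from compound 3 to compound 4 (beyond the scatter) on the shared core. The six-membered ring stays, yet without the methyl link compound 4 gives 0% and shows no response.

From the compounds shown here alone, whether a longer chain such as (piperidin-4-yl)ethyl, or an open-chain amine, would restore or raise the response at this place stays open. Nothing shown here gives a reason for this step.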